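A few compounds are considered here, and "the series" means these few. Any claim that something is new, unique, unknown or untested is made for them only; others in the source may bear on it.

Measured compounds:

Compound 1 `CN1C/C(=C\c2ccc(Cl)cc2)C(=O)[C@@]2(C1)[C@H](c1ccc(Cl)cc1)CN(C)[C@]21C(=O)Nc2ccccc21` — 61.5%
Compound 2 `CN1C/C(=C\c2ccc(Cl)cc2)C(=O)[C@@]2(C1)[C@H](c1ccc(Cl)cc1)CN(C)[C@]21C(=O)N(C)c2ccccc21` — 62%
Compound 3 `COc1ccc([C@@H]2CN(C)[C@]3(C(=O)Nc4ccccc43)[C@]23Cc2ccccc2C3=O)cc1` — 33.3%

All three were tested in a functional assay on RPMI18226 cells (Homo sapiens) for antiproliferative activity, read by sulforhodamine B assay, with a stated time of 48 h, tested at 10 uM; a lower number here means less inhibition, a higher number more inhibition at the concentration tested (going by the name of the read-out). Compound 1 and compound 2 share one core and differ only in that compound 2 carries methyl in place of hydrogen on an amide-type nitrogen in a ring. The step of a number 0.5 percentage points higher from compound 1 to compound 2 (within the scatter) is within the scatter, so these two values cannot be told apart. Compound 3 has a different core; how the two cores differ is not broken down here. In this assay compound 3 gives 33.3%, the lowest of the three numbers, and the gaps to compound 1 and to compound 2 are both beyond the scatter.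

Compound 4 `COc1ccc([C@@H]2CN(C)[C@]3(C(=O)N(C)c4ccccc43)[C@]23Cc2ccccc2C3=O)cc1` has not yet been measured. It stands to compound 3 as compound 2 stands to compound 1: it carries methyl in place of hydrogen on an amide-type nitrogen in a ring. The surroundings are not identical, since in compound 3 the ring system counts five rings where compound 1 has four, so this is the same kind of change rather than the same change. Among the compounds with values here, the one earlier example, the step from compound 1 to compound 2, did not move the read-out beyond the scatter. On that basis, and on that alone, the step of a number 0.7 percentage points higher from compound 3 to compound 4 (within the scatter) is expected to be small. Compound 4 is therefore estimated to give about 34% in this assay, most likely between 20% and 48%.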

Compound 4, a percentage reported as inhibition, at one concentration (the size of the read-out at that concentration, not a potency): 82.3%
The estimate for compound 4 lay 48.3 percentage points below the measured number; measured number above the stated range.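

In this assay, putting a methyl in place of the amide hydrogen on the core of compound 3 gives a large step: a number 49 percentage points higher from compound 3 to compound 4 (beyond the scatter). The same kind of change therefore does not bring a step of the same size on both cores: the same change on two cores in this assay, a number 0.5 percentage points higher (within the scatter) from compound 1 to compound 2 and a number 49 percentage points higher (beyond the scatter) from compound 3 to compound 4, 48.5 percentage points apart, beyond the scatter of two such steps. Within the data shown here, this shows that a result for this change on one core cannot simply be carried over to the other core, but with only two pairs it does not show which of the differences between the cores matters, nor how the change would behave on any third core, and since each number is a reading at a single concentration, it does not give a difference in potency.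

The compounds shown carry only hydrogen or methyl on this nitrogen, so it remains open whether an ethyl group, a longer chain or a benzyl group there would extend the large step seen on the core of compound 3 or lose it. Going by these compounds, it also remains open whether the same methyl would give a large step on a version of this core with a different group in place of the methoxy group of compound 3 and compound 4.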